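This account rests on a few compounds, and the source may have more. Where it says the series, first, only, none or still open, it means among the compounds named here.

Two compounds share one core and differ only in the group on an amine nitrogen. Compound 1 `CC(=O)N(CC(C1CCCCC1)N1CCN(C(=O)[C@@H]2CN(C(C)(C)C)C[C@H]2c2ccc(F)cc2F)CC1)C(C)C` carries an acetyl there, and in an assay on CHO cells for displacement of a labelled ligand from Melanocyte-stimulating hormone receptor (Homo sapiens) (on this read-out higher numbers stand for weaker inhibition and lower numbers for stronger inhibition), compound 1 gives 1800 nM. Compound 2 `CC(C)N(CC(C1CCCCC1)N1CCN(C(=O)[C@@H]2CN(C(C)(C)C)C[C@H]2c2ccc(F)cc2F)CC1)S(C)(=O)=O` carries a methylsulfonyl instead, and in this assay compound 2 gives 1000 nM. Among the compounds with values here, the single measured step, a 1.8-fold lower number from compound 1 to compound 2 (0.26 log units; within the scatter), shows that swapping these two groups hardly moves the number. Compound 2 thus holds the lower of the two numbers, but by a margin within the scatter, so neither compound can be called the stronger one.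

Compound 3 `CC(C)N(CC(C1CCCCC1)N1CCN(C(=O)[C@@H]2CN(C(C)(C)C)C[C@H]2c2ccc(F)cc2F)CC1)C(=O)c1cccnn1` takes the next step: (pyridazin-3-yl)carbonyl in place of methylsulfonyl on an amine nitrogen. Within the data shown here, only the step from compound 1 to compound 2 bears on this, and it was small; nothing measured yet tells how a ring on the carbonyl changes things. The expectation for compound 3 is therefore a step of a 1.5-fold higher number from compound 2 to compound 3 (0.18 log units; within the scatter), no change beyond the scatter. Compound 3 is estimated at 1500 nM in this assay, with a range of 500 nM to 4500 nM.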

Compound 3, half-maximal inhibitory concentration: 1900 nM
For compound 3 the middle estimate is 1.3-fold (0.10 log units) below the measured one, within the range that was stated.
By their numbers in this assay, from the lowest: compounds 2, 1 and 3 (each within the scatter of the next).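

Replacing the methylsulfonyl with the larger (pyridazin-3-yl)carbonyl gives a 1.9-fold higher number from compound 2 to compound 3 (0.28 log units; within the scatter) in this assay, while replacing the methyl of the acetyl with pyridazin-3-yl gives a 1.1-fold higher number from compound 1 to compound 3 (0.02 log units; within the scatter). The earlier pair compared only two small groups, whereas these steps show that, among these three compounds, the amine nitrogen can carry a group of 8 heavy atoms with a six-membered aromatic ring, in place of one of 4 heavy atoms with no ring, without any step leaving the scatter. No measured information is available to explain why the values stay so close together.

From the compounds shown here alone, it remains open whether a different group on the carbonyl, such as a plain phenyl ring, a saturated piperidine ring, or a pyridazine ring bearing an amine or a carboxylic acid, would move the number beyond the scatter in either direction. Going by these compounds, it is also open whether the same insensitivity would hold if the isopropyl on that nitrogen gave way to a longer chain or a cyclopropyl group.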